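Methoxycarbonyl to Hydroxymethyl: an Expected Drop in Cytotoxicity

The source may report more compounds than this note shows. Statements on the series, on what has been measured and on what is new or still open speak of the compounds shown alone.

Measured so far in a functional assay on DU-145 cells (Homo sapiens) for cytotoxicity, read by MTT assay; on this read-out lower numbers stand for stronger inhibition and higher numbers for weaker inhibition:
- compound 1, `COC(=O)C[C@@H]1C[C@@H](O)[C@H](C)[C@H](c2ccccc2)N1`, gives 6300 nM
- compound 2, `COC(=O)C[C@H]1C[C@H](O)[C@@H](C)[C@@H](c2ccc(OC)cc2)N1`, gives 6500 nM
- compound 3, `C[C@H]1[C@H](O)C[C@@H](CCO)N[C@H]1c1ccccc1`, gives 41600 nM

Compound 1 and compound 2 share most of their structure, but how their two cores differ is not broken down here; their values in this assay lie within the usual scatter of each other, so no order between them can be claimed.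

Compound 3 is compound 1 with one change: hydroxymethyl in place of methoxycarbonyl on a saturated chain carbon bound to a saturated ring carbon. That change produced a 6.6-fold higher number from compound 1 to compound 3 (0.82 log units; beyond the scatter), a clearly weaker cytotoxic effect.

Compound 4, `COc1ccc([C@H]2N[C@@H](CCO)C[C@H](O)[C@H]2C)cc1`, has not yet been tested. It stands to compound 2 exactly as compound 3 stands to compound 1: hydroxymethyl in place of methoxycarbonyl on a saturated chain carbon bound to a saturated ring carbon. The place of the change is described in the same words for both pairs, so this is the same change, made once on each core.

For the measured compounds named here, with only one measured example of this change, the expectation for compound 4 rests on that single step. Because compound 1 gave 6300 nM and compound 3 gave 41600 nM, a step of about the same size is expected here, namely a 6.5-fold higher number from compound 2 to compound 4 (0.81 log units; beyond the scatter). Compound 4 is therefore estimated at 42000 nM in this assay, most likely between 15000 nM and 120000 nM. Whether the change behaves alike on both cores is exactly what the measurement will show.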

Compound 4, half-maximal inhibitory concentration: 14800 nM
Compound 4: middle estimate off by 2.8-fold (0.45 log units), on the high side; the whole stated range lies above it.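

In this assay, putting hydroxymethyl in place of methoxycarbonyl weakened the cytotoxic effect on the second core as well, giving a 2.3-fold higher number from compound 2 to compound 4 (0.36 log units; beyond the scatter), so the direction of the step carried over from the core of compound 1 to the core of compound 2. The size of the step did not carry over, and the gap between the two steps is larger than repeat measurements alone would be expected to produce: the same change on two cores in this assay, a 6.6-fold higher number (0.82 log units; beyond the scatter) from compound 1 to compound 3 and a 2.3-fold higher number (0.36 log units; beyond the scatter) from compound 2 to compound 4, 2.9-fold (0.46 log units) apart, beyond the scatter of two such steps This shows that, in this series, one measured step gives a fair guide to direction but a poor guide to size, yet two pairs of compounds cannot show which feature of the cores sets the size, and they establish no rule for any core beyond these two.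

The compounds shown leave open how other groups would behave at the same place, on a saturated chain carbon bound to a saturated ring carbon, such as a carboxylic acid, an amide or a chain longer than 2-hydroxyethyl. They also leave open whether a third core would give a step closer to the larger one or to the smaller one.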